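Adding One Methyl to the Ester Side Chain

The source may hold more compounds than are shown below. What is called first, only, known or untested is meant among the compounds shown, and "the series" means these compounds.

Measured in a functional assay on SF-268 cells (Homo sapiens) for cytotoxicity, read by MTT assay, with a stated time of 24 h; on this read-out higher numbers stand for weaker inhibition and lower numbers for stronger inhibition
Compound 1 `C=C[C@@]1(C)[C@H]2OC(=O)C(=C)[C@H]([C@@H]2OC(C)=O)[C@H](OC(=O)C(C)(C)O)[C@@H]1C(=C)C=O` gives 440 nM
Compound 2 `C=C1C(=O)O[C@H]2[C@@H](OC(C)=O)[C@@H]1[C@H](OC(=O)C(C)(C)O)[C@H](C(=C)C=O)[C@@]2(C)[C@@H]1CO1` gives 640 nM

Only these two numbers are available, and compound 2 stands within the scatter of compound 1. Within the data shown here, the single measured step is a 1.5-fold higher number from compound 1 to compound 2 (0.16 log units; within the scatter) and comes from oxiran-2-yl in place of vinyl on a saturated ring carbon. Compound 3 `C=C1C(=O)O[C@H]2[C@@H](OC(C)=O)[C@@H]1[C@H](OC(=O)C(C)(O)CC)[C@H](C(=C)C=O)[C@@]2(C)[C@@H]1CO1` carries a different change from compound 2, namely methyl in place of hydrogen on a saturated chain carbon, two bonds along the chain from a carbonyl carbon and an oxygen on a saturated carbon and this turns 1-hydroxy-1-methylethyl into 1-hydroxy-1-methylpropyl. Among the measured compounds shown here, no measured step tests that change, so the one step available offers only weak guidance. With nothing pointing either way, no shift beyond the scatter is expected in this assay. The expected change is a 1.1-fold lower number from compound 2 to compound 3 (0.03 log units; within the scatter). For compound 3 the estimate is 600 nM, with an expected range from 280 nM to 1300 nM.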

Compound 3, half-maximal inhibitory concentration: 290 nM
The estimate for compound 3 lay 2.1-fold (0.32 log units) above the measured number; low and high end bracket the measured number.
By their numbers in this assay, from the lowest: compounds 3, 1 and 2 (each within the scatter of the next, the first and the last beyond it).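

Adding one methyl to the ester side chain, which turns 1-hydroxy-1-methylethyl into 1-hydroxy-1-methylpropyl, gives in this assay a change of its own: a 2.2-fold lower number from compound 2 to compound 3 (0.34 log units; beyond the scatter). The earlier step, at the vinyl group, stayed within the scatter, whereas this one lies just beyond it, so this chain carbon accepts one more carbon with no loss on this read-out, though the shift is modest and rests on one pair of compounds. Nothing available here explains the shift. Going by these compounds, whether the trend continues with a longer chain such as 1-hydroxy-1-methylbutyl remains open, as does the effect of an amine in place of the hydroxyl group on this chain. Also open, on these data alone, is whether the same methyl would act alike on compound 1, which carries vinyl rather than oxiran-2-yl.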